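Pyridin-4-yl in place of pyridin-2-yl

This account rests on a few compounds, and the source may have more. Where it says the series, first, only, none or still open, it means among the compounds named here.

Within the data shown here, in a functional assay on HeLa cells (Homo sapiens) for cytotoxicity, read by ELISA, with a stated time of 2 days (on this read-out higher numbers stand for weaker inhibition and lower numbers for stronger inhibition), compound 1 `Oc1cccc(-c2cc(-c3ccccc3)nc(-c3ccsc3)c2)c1` gives 14900 nM and compound 2 `Oc1cccc(-c2cc(-c3ccccc3)nc(-c3ccccn3)c2)c1` gives 29800 nM, so compound 2 stands within the scatter of its only neighbour. Compound 3 `Oc1cccc(-c2cc(-c3ccccc3)nc(-c3ccncc3)c2)c1` carries pyridin-4-yl in place of pyridin-2-yl on an aromatic carbon. Among the measured compounds shown here, one measured step bears on this: the exchange of thiophen-3-yl for pyridin-2-yl, a 2.0-fold higher number from compound 1 to compound 2 (0.30 log units; within the scatter), stays within the scatter. No step beyond the scatter is therefore expected in this assay, and the estimate amounts to an expected 1.5-fold lower number from compound 2 to compound 3 (0.17 log units; within the scatter). Compound 3 is expected at 20000 nM, with an estimated range of 8000 nM to 50000 nM.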

Compound 3, half-maximal inhibitory concentration: 15000 nM
Beside the measured number, compound 3's estimate is 1.3-fold (0.12 log units) above it; low and high end bracket the measured number.
By their numbers in this assay, from the lowest: compounds 1, 3 and 2 (each within the scatter of the next).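

In this assay, pyridin-4-yl in place of pyridin-2-yl on the aromatic carbon gives a 2.0-fold lower number from compound 2 to compound 3 (0.30 log units; within the scatter) and pyridin-4-yl in place of thiophen-3-yl gives a 1.0-fold higher number from compound 1 to compound 3 (0.00 log units; within the scatter) and both steps lie within the scatter. The two pyridine isomers, which have the same atoms joined differently, are thus not told apart at this position, and none of the three aromatic rings shown is set apart from the others. From the compounds shown here alone, whether an amine, a carboxylic acid or a longer alkyl chain on this carbon would give a step beyond the scatter stays open. No measured evidence bears on why these three compounds read alike.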